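Replacing the Fluorinated Aryl of Compound 1 with Phenethyl

The compounds below may be only part of what the source reports. "The series", "measured", "known", "first", "only" and "open" are said of these compounds alone.

Compound 1 `Cc1cc(-c2cc(Cl)cc(Cl)c2/C=C/[C@@H]2C[C@@H](O)CC(=O)O2)ccc1F`: 29 nM
Compound 2 `O=C1C[C@H](O)C[C@@H](/C=C/c2c(F)cc(F)cc2-c2ccc(F)cc2)O1`: 860 nM
Compound 3 `Cc1cc(Cl)c(/C=C/[C@@H]2C[C@@H](O)CC(=O)O2)c(-c2ccc(F)c(C)c2)c1`: 13 nM

In an assay for inhibition of 3-hydroxy-3-methylglutaryl-coenzyme A reductase (Rattus norvegicus) (a lower number here means a stronger inhibitor, a higher number a weaker inhibitor), compound 1 stands second highest of the three numbers; compound 3 sits closest, and the step of a 2.2-fold lower number from compound 1 to compound 3 (0.35 log units; beyond the scatter) is modest, while compound 2 lies far above. Compound 4 `O=C1C[C@H](O)C[C@@H](/C=C/c2c(Cl)cc(Cl)cc2CCc2ccccc2)O1` differs from compound 1 in one place: phenethyl in place of 4-fluoro-3-methylphenyl on an aromatic carbon. Going by the values given here, no measured step covers this change; the only single-point step concerns a methyl replacing a chloro and is small. Compound 2, which differs from compound 1 in several places, shows that the series can span a wide range. Compound 4 is expected to give a higher number, a step of a 5.2-fold higher number from compound 1 to compound 4 (0.71 log units; beyond the scatter). The estimate for compound 4 in this assay is 150 nM, within 40 nM to 600 nM.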

Compound 4, half-maximal inhibitory concentration: 430 nM
Compound 4: the middle estimate sits 2.9-fold (0.46 log units) below what was measured; measured number inside the range.
By their numbers in this assay, from the lowest: compound 3; then compound 1; then compounds 4 and 2 (each within the scatter of the next).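

In this assay, phenethyl in place of 4-fluoro-3-methylphenyl is the first single change shown at this position, and it gives a 15-fold higher number from compound 1 to compound 4 (1.17 log units; beyond the scatter). The position therefore responds strongly to this swap, even though both groups have the same heavy-atom count, one six-membered aromatic ring of carbon only, and no hydrogen-bond donors or acceptors. Nothing measured here explains the rise. Still open, as far as these compounds go, is whether the rise tracks the chain of phenethyl or the absent fluoro and methyl groups. From the compounds shown here alone, how a plain phenyl, benzyl or a longer chain would read here also remains unknown.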